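The compounds below may be only part of what the source reports. "The series", "measured", "known", "first", "only" and "open" are said of these compounds alone.

The measured compounds:

- compound 1, `COc1ccc(Cc2nnc(CN(c3cccc(Cl)c3C)S(=O)(=O)c3ccc(C)cc3)o2)cc1`, in an assay on CHO cells for displacement of a labelled ligand from prostaglandin E2 receptor EP1 subtype (Homo sapiens) (a lower number here means a stronger inhibitor, a higher number a weaker inhibitor), gives 6.31 nM
- compound 2, `CCOc1ccc(Cc2nnc(CN(c3cccc(Cl)c3C)S(=O)(=O)c3ccc(C)cc3)o2)cc1`, in this assay gives 3.98 nM
- compound 3, `Cc1ccc(S(=O)(=O)N(Cc2nnc(Cc3ccc(C(F)(F)F)cc3)o2)c2cccc(Cl)c2C)cc1`, in this assay gives 50.1 nM

Compound 3 has the highest number of the three, that is, it is the weakest inhibitor shown. The steps to it are a 7.9-fold higher number from compound 1 to compound 3 (0.90 log units; beyond the scatter) and a 13-fold higher number from compound 2 to compound 3 (1.10 log units; beyond the scatter), both beyond the scatter, while a 1.6-fold lower number from compound 1 to compound 2 (0.20 log units; within the scatter) lies within it. Compound 4, `Cc1ccc(S(=O)(=O)N(Cc2nnc(Cc3ccccc3F)o2)c2cccc(Cl)c2C)cc1`, is not yet measured. It differs from compound 3 by 2-fluorophenyl in place of 4-(trifluoromethyl)phenyl on a saturated chain carbon bound to an aromatic carbon. Among the compounds with values here, no measured step involves a fluorine on this ring, so the two steps that bear on it only show that removing the trifluoromethyl in favour of an ether group lowered the number noticeably. On that basis a moderate step downward is expected for compound 4, estimated as a 2.5-fold lower number from compound 3 to compound 4 (0.40 log units; beyond the scatter). Compound 4 is therefore estimated in this assay at 20 nM, within a range of 5 nM to 80 nM.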

Compound 4, half-maximal inhibitory concentration: 501 nM
Beside the measured number, compound 4's estimate is 25-fold (1.40 log units) below it; the whole stated range lies below it.
By their numbers in this assay, from the lowest: compounds 2 and 1 (each within the scatter of the next); then compound 3; then compound 4.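

At this position, on a saturated chain carbon bound to an aromatic carbon, the spread in this assay proves much wider than the first three compounds showed: 2-fluorophenyl in place of 4-(trifluoromethyl)phenyl gives a 10-fold higher number from compound 3 to compound 4 (1.00 log units; beyond the scatter) and so takes the series well past its earlier weakest point. Against the ether-bearing rings the change is larger still, with a 79-fold higher number from compound 1 to compound 4 (1.90 log units; beyond the scatter) and a 130-fold higher number from compound 2 to compound 4 (2.10 log units; beyond the scatter), which makes compound 4 the weakest inhibitor of the four. Nothing available explains why this change costs so much.

The compounds shown leave open whether the loss goes with the fluorine itself or with where it sits on the ring, which 4-fluorophenyl and plain phenyl could separate. From the compounds shown here alone, how a ring carrying an amine or a carboxylic acid would behave here also remains open.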